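Trimethoxyphenyl Shift Expected to Lift Growth Inhibition Again

The source may hold more compounds than are shown below. What is called first, only, known or untested is meant among the compounds shown, and "the series" means these compounds.

Compound 1 `COc1cc(/C=C/C(=O)/C=C/c2ccccc2)ccc1OCc1cn(CCCCOc2cc(=O)oc3ccccc23)nn1` gives 31% in a functional assay on COLO 205 cells (Homo sapiens) for inhibition, read by sulforhodamine B assay, with a stated time of 48 h, tested at 50 uM; a higher number here means more inhibition of growth at the concentration tested, a lower number less inhibition of growth.
Compound 2 `COc1cc(/C=C/C(=O)/C=C/c2cc(OC)c(OC)c(OC)c2)ccc1OCc1cn(CCCCOc2cc(=O)oc3ccccc23)nn1` gives 60% in this assay.
Compound 3 `COc1cc(/C=C/C(=O)/C=C/c2ccccc2)ccc1OCc1cn(CCCCCOc2cc(=O)oc3ccccc23)nn1` gives 22% in this assay.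

Compound 1 and compound 2 share a core and differ in one place, (3,4,5-trimethoxyphenyl in place of phenyl on a double-bonded chain carbon bound to a double-bonded chain carbon). This change brought a number 29 percentage points higher from compound 1 to compound 2 (beyond the scatter). Compound 3 stands on a different core; the difference between the two cores is not broken down here. Compound 4 `COc1cc(/C=C/C(=O)/C=C/c2cc(OC)c(OC)c(OC)c2)ccc1OCc1cn(CCCCCOc2cc(=O)oc3ccccc23)nn1` is not yet measured, and it differs from compound 3 by the same change, (3,4,5-trimethoxyphenyl in place of phenyl on a double-bonded chain carbon bound to a double-bonded chain carbon). Because the earlier step gave a number 29 percentage points higher from compound 1 to compound 2 (beyond the scatter), a step of similar size is expected from compound 3 to compound 4, namely a number 29 percentage points higher from compound 3 to compound 4 (beyond the scatter). Compound 4 is therefore estimated at 51%, likely between 35% and 67%.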

Compound 4, percent growth inhibition at one concentration: 51%
The estimate for compound 4 equals the measured number at the digits printed; measured number inside the range.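

In this assay, 3,4,5-trimethoxyphenyl in place of phenyl gave a number 29 percentage points higher from compound 3 to compound 4 (beyond the scatter), so the change carried over from the core of compound 1 to the core of compound 3. The two steps match in size: the same change on two cores in this assay, a number 29 percentage points higher (beyond the scatter) from compound 1 to compound 2 and a number 29 percentage points higher (beyond the scatter) from compound 3 to compound 4, 0 percentage points apart, within the scatter of two such steps. This shows that the change transferred between these two cores in this one assay, but it does not show why growth inhibition rises or whether the same step would appear on any further core.

The compounds shown leave open how a phenyl bearing an amine or a carboxylic acid would compare in this place. They also leave open whether the step would persist with a longer chain.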